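A few compounds are considered here, and "the series" means these few. Any claim that something is new, unique, unknown or untested is made for them only; others in the source may bear on it.

Compound 1, `O=C1c2ccccc2C(=O)N1c1ccccc1[N+](=O)[O-]`, is the weaker of the two compounds measured in an assay on isolated protein for binding affinity to sodium channel protein type 2 subunit alpha (Homo sapiens) (a higher number here means a weaker inhibitor, a lower number a stronger inhibitor), where compound 1 gives 134000 nM. The other measured compound, compound 2, `NS(=O)(=O)c1nnc(N2C(=O)c3ccccc3C2=O)s1`, gives 61100 nM in this assay, a number somewhat lower than that of compound 1 and beyond the scatter. Compound 3, `COc1ccc(N2C(=O)c3ccccc3C2=O)c([N+](=O)[O-])c1`, differs from compound 1 by methoxy in place of hydrogen on an aromatic carbon. For the measured compounds named here, no measured pair shows this change, so the step from compound 1 to compound 3 is expected to be small, a 1.3-fold lower number from compound 1 to compound 3 (0.13 log units; within the scatter), in no firm direction and likely within the scatter. Compound 3 is thus estimated at 100000 nM, with a range from 40000 nM to 250000 nM.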

Compound 3, inhibition constant: 108000 nM
For compound 3 the middle estimate is 1.1-fold (0.03 log units) below the measured one; measured number inside the range.
By their numbers in this assay, from the lowest: compounds 2, 3 and 1 (each within the scatter of the next, the first and the last beyond it).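

In this assay, methoxy in place of hydrogen on an aromatic carbon, meta to a nitro group and para to a large group, can now be read on a measured pair, with a 1.2-fold lower number from compound 1 to compound 3 (0.09 log units; within the scatter) as the step. The position therefore carries methoxy while compound 3 stays within the scatter of compound 1. Nothing available bears on the reason for this result. On these data alone, whether an amine, a carboxylic acid or a longer chain such as ethoxy would also stay within the scatter here remains open. So does the outcome of methoxy on the other carbons of this ring.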